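Replacing the non-aromatic ring with 4H-1,2,4-triazol-3-yl

The compounds below may be only part of what the source reports. "The series", "measured", "known", "first", "only" and "open" are said of these compounds alone.

Measured in an ADME assay on microsomes from liver (Homo sapiens) for metabolic stability; a higher number here means that the compound lasts longer, a lower number that the compound disappears faster:
- compound 1 `CC(C)C(Nc1nnc[nH]1)c1ccc(-c2ccc3cccc(F)c3c2)[nH]c1=O`: > 3 h (a limit)
- compound 2 `CC(C)C(c1ccc(-c2ccc3cccc(F)c3c2)[nH]c1=O)N1CCN/C1=N\C#N`: 0.632 h

Compound 1 sits at the limit of > 3 h in this assay, at which 1 of the 2 values shown sits. For the measured compounds named here, compound 2 therefore holds the only actual number, 0.632 h.

The change to compound 3 `CC(C)C(c1nnc[nH]1)c1ccc(-c2ccc3cccc(F)c3c2)[nH]c1=O` is a group of 5 heavy atoms (2 carbon, 3 nitrogen; one five-membered aromatic ring with 3 hetero atoms) in place of a group of 8 heavy atoms (4 carbon, 4 nitrogen; one five-membered non-aromatic ring with 2 hetero atoms), on a saturated chain carbon bound to an aromatic carbon and a saturated chain carbon. Going by the values given here, the group in compound 1 also has a five-membered aromatic ring with 3 hetero atoms, so the one measured step that bears on this change is an at least 4.7-fold lower number from compound 1 to compound 2 (0.67 log units; beyond the scatter). A change of similar size in the opposite direction is expected, estimated as a 4.0-fold higher number from compound 2 to compound 3 (0.60 log units; beyond the scatter). For compound 3 the estimated half-life is 2.5 h, with an expected range of 0.9 h to 6 h.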

Compound 3, half-life: 0.905 h
Beside the measured number, compound 3's estimate is 2.8-fold (0.44 log units) above it, and the stated range covers the measured number.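

On the saturated chain carbon, 4H-1,2,4-triazol-3-yl in place of the non-aromatic ring group leaves the half-life in this assay within the scatter (a 1.4-fold higher number from compound 2 to compound 3 (0.16 log units; within the scatter)). The aromatic triazole ring alone therefore does not match compound 1: with the ring kept, removing the amino link gives a clear loss (an at least 3.3-fold lower number from compound 1 to compound 3 (0.52 log units; beyond the scatter)). The value of compound 1 is a limit, so this step gives only a bound: the limit of > 3 h in this assay, at which 1 of the 3 values shown sits.

From the compounds shown here alone, how far the half-life of compound 1 extends stays open. Also open, going by these compounds, is whether a methylamino link or an ether oxygen link would serve like the amino link.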